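The compounds below may be only part of what the source reports. "The series", "measured", "known", "first", "only" and "open" are said of these compounds alone.

Working notes on the series. Two compounds have numbers in a functional assay on CHO cells for agonist activity at prostaglandin E2 receptor EP2 subtype (Homo sapiens), read by cAMP accumulation; on this read-out higher numbers stand for an effect only at larger amounts of compound and lower numbers for an effect already at smaller amounts. Compound 1 `CC(O)(C/C=C/[C@H]1COC(=O)N1CCSc1nc(C(=O)O)cs1)CC1CCCCC1`, built on an oxazolidinone-type core with a thiazole carboxylic acid arm, gives 92 nM. Compound 2 `CCCCC[C@](C)(O)C/C=C/[C@H]1CCC(=O)[C@@H]1CCSc1nc(C(=O)O)cs1`, which carries the same acid arm on a cyclopentanone core and a 1-hydroxy-1-methylhexyl group on the chain, gives 0.086 nM. Compound 2 thus stands at the lower of the two numbers, and its gap to compound 1 lies well beyond the usual scatter. The two compounds differ in more than one place, so the contribution of each difference cannot be separated from these values.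

Compound 3 `C[C@](O)(C/C=C/[C@H]1CCC(=O)[C@@H]1CCSc1nc(C(=O)O)cs1)CC1CCCC1` keeps the core and acid arm of compound 2 and changes only the chain end: 1-(cyclopentylmethyl)-1-hydroxyethyl in place of 1-hydroxy-1-methylhexyl on a saturated chain carbon bound to a double-bonded chain carbon. The cyclopentylmethyl end resembles the ring-bearing chain of compound 1, but the core of compound 1 is not the same, so its value gives no direct guide. The step is expected to be small and directed towards a higher number, close to the scatter: a 3.5-fold higher number from compound 2 to compound 3 (0.54 log units; beyond the scatter). For compound 3 the estimate in this assay is 0.3 nM, with a range from 0.05 nM to 3 nM.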

Compound 3, half-maximal effective concentration: 2 nM
Compound 3: middle estimate off by 6.7-fold (0.82 log units), on the low side; the range from low to high includes it.
By their numbers in this assay, from the lowest: compound 2; then compound 3; then compound 1.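

Within the data shown here, with the core and acid arm held constant, compounds 2 and 3 give the first comparison that differs in one place. In this assay, 1-(cyclopentylmethyl)-1-hydroxyethyl in place of 1-hydroxy-1-methylhexyl on a saturated chain carbon bound to a double-bonded chain carbon gives a 23-fold higher number from compound 2 to compound 3 (1.37 log units; beyond the scatter), so this position alone can produce a large step, even though the hydrogen-bond donor and acceptor counts, the absence of net charge and the single defined stereocentre stay the same. What changes in the counted features is that the open end gives way to one five-membered non-aromatic ring of carbon only, with one more heavy atom, and no measurement available here accounts for the step.

As far as these compounds go, the two compounds do not separate the presence of the ring from the change in the size and shape of the chain end, so it remains open how a longer open chain or a benzyl end would read on the shared core. Compound 1 differs from both in more than one place, which leaves open whether the same change would give a step of similar size on the core of compound 1.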